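The source may hold more compounds than are shown below. What is called first, only, known or untested is meant among the compounds shown, and "the series" means these compounds.

Three close relatives share one core. Compound 1 `Cc1ccc(NC2=CC(=O)c3nc4n(c3C2=O)[C@H]2OC[C@@H](O)[C@H]2OC4)cc1` carries a methyl on an aromatic carbon, and in a functional assay on ECa-109 cells for inhibition, with ECa-109 cell line (Homo sapiens) as the target, read by sulforhodamine B assay (a lower number here means a stronger inhibitor, a higher number a weaker inhibitor), compound 1 gives 3480 nM. Compound 2 `O=C1C(Nc2cccc(Cl)c2)=CC(=O)c2c1nc1n2[C@H]2OC[C@@H](O)[C@H]2OC1` carries a chloro instead, and in this assay compound 2 gives 3080 nM. Compound 3 `O=C1C=C(Nc2ccc(Br)cc2)C(=O)c2c1nc1n2[C@H]2OC[C@@H](O)[C@H]2OC1` carries a bromo, and in this assay compound 3 gives 2850 nM. Compound 2 thus sits among its two neighbours, all three values within the usual scatter of one another. Within the data shown here, the only measured step of this kind, bromo in place of methyl on an aromatic carbon, read a 1.2-fold lower number from compound 1 to compound 3 (0.09 log units; within the scatter). Compound 4 `O=C1C(Nc2cccc(F)c2)=CC(=O)c2c1nc1n2[C@H]2OC[C@@H](O)[C@H]2OC1` differs from compound 2 by fluoro in place of chloro on an aromatic carbon. Among the measured compounds shown here, since the one halogen swap seen read a 1.2-fold lower number from compound 1 to compound 3 (0.09 log units; within the scatter), the expected step is a 1.0-fold lower number from compound 2 to compound 4 (0.01 log units; within the scatter). Compound 4 is expected to give 3000 nM in this assay, between 1500 nM and 6000 nM.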

Compound 4, half-maximal inhibitory concentration: 2370 nM
Compound 4: middle estimate off by 1.3-fold (0.10 log units), on the high side, and the stated range covers the measured number.
By their numbers in this assay, from the lowest: compounds 4, 3, 2 and 1 (each within the scatter of the next).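

Changing one halogen for another at this place, on an aromatic carbon meta to a large group, reads a 1.3-fold lower number from compound 2 to compound 4 (0.11 log units; within the scatter) in this assay. So 3-chlorophenyl and 3-fluorophenyl cannot be told apart here, and this is the first direct swap of one halogen for another at a single position. Nothing measured here explains this result. Still open, going by these compounds, is whether an amine, a carboxylic acid or a longer chain in place of the halogen would shift the number beyond the scatter. The same chloro-to-fluoro change at another place on the ring also remains untested among these compounds.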